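A few compounds are considered here, and "the series" means these few. Any claim that something is new, unique, unknown or untested is made for them only; others in the source may bear on it.

Measured so far in a functional assay on the whole organism (strain Wistar albino) for inhibition, with Rattus norvegicus as the target, read by paw edema, with stated times of 1 h and 4 h, at a dose of 40 mg/kg by the oral route; a higher number here means more inhibition at the dose given (going by the name of the read-out), a lower number less inhibition:
compound 1 `Cc1nc(-c2ccc(Cl)cc2)sc1C1SCC(=O)N1c1ccc(F)cc1`: 67.6%
compound 2 `Cc1nc(Cc2ccc(Cl)cc2)sc1C1SCC(=O)N1c1ccccc1`: "not active" (no number reported)

Compound 1 carries the only number shown in this assay; compound 2 is the one further entry, reported without a number. For the measured compounds named here, no two measured compounds differ in a single place, so no measured step between them is available, and the two values of compound 1 and compound 2 show only that one has a number and the other has none.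

Compound 3 `COc1ccc(N2C(=O)CSC2c2sc(-c3ccc(Cl)cc3)nc2C)cc1` is not yet measured. It differs from compound 1 as follows: methoxy in place of fluoro on an aromatic carbon. The rest of the molecule stays as in compound 1.

Going by the values given here, with no measured step to lean on, the expectation rests on compound 1 alone, which gives 67.6% in this assay. The change is a small one on the outer aromatic ring, and the step in this assay is expected to be small and to lean downward, close to the usual scatter: a number 7.6 percentage points lower from compound 1 to compound 3 (within the scatter). Compound 3 is estimated at 60%, with a range from 45% to 72%.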

Compound 3, a percentage reported as inhibition, in the whole organism at one dose (the size of the read-out at that dose, not a potency): 59.1%
For compound 3 the middle estimate is 0.9 percentage points above the measured one, within the range that was stated.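

In this assay, the step from 4-fluorophenyl to 4-methoxyphenyl, methoxy in place of fluoro on an aromatic carbon para to a large group, gives the series its first readable single change: a number 8.5 percentage points lower from compound 1 to compound 3 (within the scatter). At this position the two groups therefore cannot be separated by this read-out, and the inhibition seen at the single oral dose persists when fluoro is replaced by methoxy, so the activity of compound 1 does not depend specifically on fluoro here. No measured property bears on this result, so the data offer no explanation for the size of the step.

On these data alone, with only fluoro and methoxy compared at this position, it remains open whether the same insensitivity would hold for a free amine, a carboxylic acid or a longer chain such as butoxy. Also open, as far as these compounds go, is how the 4-chlorophenyl group on the other side of the shared core contributes, as neither compound 1 nor compound 3 varies it, and a single-dose percentage says nothing about potency.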